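The source may hold more compounds than are shown below. What is called first, only, known or untested is meant among the compounds shown, and "the series" means these compounds.

Measured in a functional assay on KBVIN cells (Homo sapiens) for antiproliferative activity, read by sulforhodamine B assay, with a stated time of 3 days; on this read-out higher numbers stand for an effect only at larger amounts of compound and lower numbers for an effect already at smaller amounts:
- compound 1 `CCCc1ccc(-c2cc(=O)c3c(o2)C(CC)(CC)C(=O)C(CC)=C3O)cc1`: 12.2 uM
- compound 2 `CCC1=C(O)c2c(oc(-c3cccc(C)c3)cc2=O)C(CC)(CC)C1=O`: 3.69 uM
- compound 3 `CCC1=C(O)c2c(oc(-c3ccc(O)c(O)c3)cc2=O)C(CC)(CC)C1=O`: 5.41 uM

Compound 3 cannot be told apart from compound 2 on these numbers, as a 1.5-fold higher number from compound 2 to compound 3 (0.17 log units; within the scatter) shows. Both lie clearly under compound 1, and the gap to compound 3 is a 2.3-fold lower number from compound 1 to compound 3 (0.35 log units; beyond the scatter).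

The next compound is compound 4 `CCC1=C(O)c2c(oc(-c3ccc(O)c(C)c3C)cc2=O)C(CC)(CC)C1=O`. It keeps the shared core and carries 4-hydroxy-2,3-dimethylphenyl in place of 3,4-dihydroxyphenyl on an aromatic carbon, next to the ring oxygen: 4-hydroxy-2,3-dimethylphenyl in place of 3,4-dihydroxyphenyl on an aromatic carbon.

For the measured compounds named here, three measured steps bear on this change, and all of them alter the same group. Replacing 4-propylphenyl with 3-methylphenyl gave a 3.3-fold lower number from compound 1 to compound 2 (0.52 log units; beyond the scatter), which is modest. Exchanging 3-methylphenyl for 3,4-dihydroxyphenyl gave only a 1.5-fold higher number from compound 2 to compound 3 (0.17 log units; within the scatter). The new group has a hydroxy group, as in compound 3, and methyl groups, as in compound 2, so it borrows from two groups that performed alike. However, no measured compound carries two methyl groups on this ring, which leaves some room for a weaker result.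

In this assay, no step beyond the scatter is expected, and the estimated change is a 1.1-fold lower number from compound 3 to compound 4 (0.05 log units; within the scatter). The expected value for compound 4 is 4.8 uM, with an estimated range from 2.2 uM to 10.5 uM.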

Compound 4, concentration for half-maximal effect: 2.75 uM
Compound 4: middle estimate off by 1.7-fold (0.24 log units), on the high side, within the range that was stated.
By their numbers in this assay, from the lowest: compounds 4, 2 and 3 (each within the scatter of the next); then compound 1.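

In this assay, for the compounds shown here, this position on the shared core takes a third kind of substituted phenyl ring with no step that can be told from scatter: 4-hydroxy-2,3-dimethylphenyl gives a 2.0-fold lower number from compound 3 to compound 4 (0.29 log units; within the scatter) against 3,4-dihydroxyphenyl, and a 1.3-fold lower number from compound 2 to compound 4 (0.13 log units; within the scatter) against 3-methylphenyl. A ring with two methyl groups therefore joins the two earlier rings as a group that cannot be separated from them here, even though it has 1 hydrogen-bond donor where 3,4-dihydroxyphenyl has 2, and it stays clear of the 4-propylphenyl compound, with a 4.4-fold lower number from compound 1 to compound 4 (0.65 log units; beyond the scatter). Nothing available explains why these three groups read so alike or why 4-propylphenyl stands apart.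

The compounds shown carry only methyl, hydroxy or propyl groups on a phenyl ring at this position, so the effect of an amine, a carboxylic acid or a fluorine on that ring remains open, as does a ring containing nitrogen in place of the phenyl. As far as these compounds go, the ethyl groups on the shared core stay the same throughout, so what changing them would do is also open.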